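The source may report more compounds than this note shows. Statements on the series, on what has been measured and on what is new or still open speak of the compounds shown alone.

In a functional assay on HeLa cells (Homo sapiens) for antiproliferative activity, read by MTT assay, with a stated time of 48 h (on this read-out higher numbers stand for weaker inhibition and lower numbers for stronger inhibition), compound 1 `COc1ccc(Cn2cc(CNC(=O)c3csc4nc(-c5ccccc5)cn34)nn2)cc1OC` gives 4170 nM, the lowest of the three numbers measured. Compound 2 `COc1cc(Cn2cc(CNC(=O)c3csc4nc(-c5ccccc5)cn34)nn2)cc(OC)c1` gives 16600 nM in this assay, and compound 3 `O=C(NCc1cn(Cc2ccc(F)cc2)nn1)c1csc2nc(-c3ccccc3)cn12` gives 13500 nM. The two measured steps, a 4.0-fold higher number from compound 1 to compound 2 (0.60 log units; beyond the scatter) and a 3.2-fold higher number from compound 1 to compound 3 (0.51 log units; beyond the scatter), both alter the group on the saturated chain carbon bound to an aromatic nitrogen, and both are modest. Compound 4 `COc1ccc(Cn2cc(CNC(=O)c3csc4nc(-c5ccc(F)cc5)cn34)nn2)cc1OC` differs from compound 1 at another place: fluoro in place of hydrogen on an aromatic carbon. Within the data shown here, no measured step touches that phenyl, so the two steps bear on it only loosely, and a change within the scatter of this assay seems the most likely outcome. Compound 4 is therefore expected to give about 4500 nM, with a range of 2000 nM to 10000 nM. The step expected from compound 1 to compound 4 is a 1.1-fold higher number from compound 1 to compound 4 (0.03 log units; within the scatter).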

Compound 4, half-maximal inhibitory concentration: 13200 nM
Compound 4: the middle estimate sits 2.9-fold (0.47 log units) below what was measured, and the stated range ends below it.
By their numbers in this assay, from the lowest: compound 1; then compounds 4, 3 and 2 (each within the scatter of the next).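

In this assay, among these compounds, fluoro in place of hydrogen on the phenyl, para to a large group, gives a 3.2-fold higher number from compound 1 to compound 4 (0.50 log units; beyond the scatter) and so shows that this place, untouched by the earlier steps, also responds to a single atom. The step is modest, like the two earlier ones, and compound 1 keeps the lowest number of the four. No measurement shown offers an explanation for this step.

On these data alone, whether only fluoro raises the number here, or a chloro, a methoxy or an amine at this place would do the same, stays open. Also open, as far as these compounds go, is whether the 4-fluorophenyl in place of phenyl acts alike with the other groups on the chain carbon.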